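From Phenyl to Methyl on a Shared Core

A few compounds are considered here, and "the series" means these few. Any claim that something is new, unique, unknown or untested is made for them only; others in the source may bear on it.

Compound 2 `OC(CCn1nc2c(Br)c(Br)c(Br)c(Br)c2n1)c1ccccc1` gives 105% in a functional assay on MCF7 cells (Homo sapiens) for antiproliferative activity, read by MTT assay, with a stated time of 48 h, tested at 25 uM (on this read-out higher numbers stand for a weaker effect at the one concentration tested and lower numbers for a stronger effect), the higher of the two numbers recorded so far; its nearest neighbour, compound 1 `OC(CCn1nc2c(Br)c(Br)c(Br)c(Br)c2n1)c1ccc(F)cc1`, gives 97%, and a number 8 percentage points higher from compound 1 to compound 2 (within the scatter). Compound 3 `CC(O)CCn1nc2c(Br)c(Br)c(Br)c(Br)c2n1` differs from compound 2 by methyl in place of phenyl on a saturated chain carbon bound to an oxygen on a saturated carbon and a saturated chain carbon. Within the data shown here, no measured step touches that place: the only step recorded concerns a fluoro on an aromatic carbon and was small. With both measured numbers so close together, the step of a number 5 percentage points lower from compound 2 to compound 3 (within the scatter) is expected to stay within the scatter. Compound 3 is therefore estimated at 100%, with a range from 85% to 115%.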

Compound 3, a percentage reported as activity, at one concentration (the size of the read-out at that concentration, not a potency): 73%
Estimate against measurement, compound 3: 27 percentage points above; measured number below the stated range.
By their numbers in this assay, from the lowest: compound 3; then compounds 1 and 2 (each within the scatter of the next).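

In this assay, methyl in place of phenyl gives a number 32 percentage points lower from compound 2 to compound 3 (beyond the scatter), and methyl in place of 4-fluorophenyl gives a number 24 percentage points lower from compound 1 to compound 3 (beyond the scatter). This saturated chain carbon is thus a place where a change moves the read-out beyond the scatter, which the fluoro step on the aromatic carbon did not show. No measurement shown here accounts for the difference. As far as these compounds go, whether an ethyl, a longer chain or an amine at this place would give a number like that of compound 3, or one nearer that of compound 2, remains open.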